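The source may report more compounds than this note shows. Statements on the series, on what has been measured and on what is new or still open speak of the compounds shown alone.

Two amides built on the same core have been taken through a functional assay on the whole organism (plasma, strain albino) for inhibition, with Rattus norvegicus as the target, with stated times of 1 h and 4 h, at a dose of 25 mg/kg by the oral route; on this read-out lower numbers stand for a weaker effect and higher numbers for a stronger effect at the one dose given. Compound 1 `COc1ccc(Cl)cc1C(=O)Nc1ccc(C2=NN(c3ccccc3)C(c3ccccc3[N+](=O)[O-])C2)cc1` carries a phenyl on one ring nitrogen and a 2-nitrophenyl on a saturated ring carbon; in this assay compound 1 gives 73.3%. Compound 2 `COc1ccc(C2CC(c3ccc(NC(=O)c4cc(Cl)ccc4OC)cc3)=NN2C(C)=O)cc1` carries instead an acetyl group on that nitrogen and a 4-methoxyphenyl on the saturated ring carbon; in this assay compound 2 gives 79.4%, the higher of the two numbers, though the gap to compound 1 lies within the usual scatter, so the two cannot be ranked against each other. Among the measured compounds shown here, they differ in two places at once, and no single-change step between them is available.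

Compound 3 `COc1ccc(Cl)cc1C(=O)Nc1ccc(C2=NN(C(C)=O)C(c3ccccc3[N+](=O)[O-])C2)cc1` keeps the acetyl group of compound 2 and alters only the saturated ring carbon: 2-nitrophenyl in place of 4-methoxyphenyl on a saturated ring carbon. The same 2-nitrophenyl is present in compound 1, whose value 73.3% sits close to that of compound 2. Nothing in the two numbers points to a swing. Compound 3 is therefore expected to move by a number 4.4 percentage points lower from compound 2 to compound 3 (within the scatter), a step not expected to exceed the scatter. The estimate for compound 3 in this assay is 75%, with a range from 62% to 87%.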

Compound 3, a percentage reported as inhibition, in the whole organism at one dose (the size of the read-out at that dose, not a potency): 77.2%
For compound 3 the middle estimate is 2.2 percentage points below the measured one; measured number inside the range.
By their numbers in this assay, from the lowest: compounds 1, 3 and 2 (each within the scatter of the next).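

Among the compounds shown here, compound 3 gives the first single-change reading at the saturated ring carbon next to the ring nitrogen. In this assay, 2-nitrophenyl in place of 4-methoxyphenyl there gives a number 2.2 percentage points lower from compound 2 to compound 3 (within the scatter) and so leaves the two compounds indistinguishable, with one aromatic ring at this place in both. For the compounds shown here, it also gives the first single-change reading on the ring nitrogen, where acetyl in place of phenyl gives a number 3.9 percentage points higher from compound 1 to compound 3 (within the scatter) and where the two compounds again cannot be told apart, while no measurement bears on why either step comes out as it does.

All of this rests on two aryl groups at the saturated ring carbon and on two groups at the ring nitrogen, read at a single oral dose, so these results say nothing yet about how far the read-out would stay the same with a quite different group. On these data alone, whether a carboxylic acid or an amine on the aromatic ring at the saturated carbon, or a longer acyl chain such as butanoyl in place of acetyl on the ring nitrogen, would produce a step beyond the scatter remains open.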